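The compounds below may be only part of what the source reports. "The series", "measured", "known", "first", "only" and "open" are said of these compounds alone.

Compound 1 `Cc1ccc(-c2ccsc2S(=O)(=O)NCCNC(=S)Nc2ccc([N+](=O)[O-])cc2)c(Oc2ccc(O)c(O)c2)c1` was tested in a functional assay on HL-60 cells (Homo sapiens) for inhibition, read by CCK-8 assay, with a stated time of 48 h (on this read-out lower numbers stand for stronger inhibition and higher numbers for weaker inhibition), where compound 1 gives 2900 nM. For the measured compounds named here, only one other compound has a number here: compound 2 `O=C(NCCNS(=O)(=O)c1ccc(-c2ccccc2OCc2cccc(O)c2)s1)Nc1cc(Cl)cc(Cl)c1` gives 2800 nM in this assay. Of the two, compound 1 has the higher number, but the two values lie within the usual scatter of repeated measurements, so they cannot be told apart.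

Compound 3 `COc1ccc(NC(=O)NCCNS(=O)(=O)c2sccc2-c2ccc(C)cc2Oc2ccc(O)c(O)c2)cc1` has not yet been measured. It is made from compound 1 by a single change: a group of 11 heavy atoms (8 carbon, 1 nitrogen, 2 oxygen; one six-membered aromatic ring of carbon only) in place of a group of 12 heavy atoms (7 carbon, 2 nitrogen, 2 oxygen, 1 sulfur; one six-membered aromatic ring of carbon only), on an amine nitrogen. Going by the values given here, no measured pair in this set shares exactly that change, so there is no step to lean on. What can be said is that compound 2, which also carries a carbamoyl group bearing a substituted aromatic ring rather than the group leaving compound 1, sits within the scatter of compound 1, which offers no hint of a large shift.

Compound 3 is therefore expected to stay close to its parent, with an expected step of a 1.0-fold higher number from compound 1 to compound 3 (0.01 log units; within the scatter) that is not beyond the scatter. The estimate for compound 3 in this assay is 3000 nM, with a range from 1000 nM to 9000 nM.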

Compound 3, half-maximal inhibitory concentration: 6100 nM
Estimate against measurement, compound 3: 2.0-fold (0.31 log units) below; low and high end bracket the measured number.
By their numbers in this assay, from the lowest: compounds 2 and 1 (each within the scatter of the next); then compound 3.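

For the compounds shown here, only the group on an amine nitrogen whose other neighbour is a saturated chain carbon changes here, so this pair gives the first direct reading of that position: in this assay, placing (4-methoxyphenyl)carbamoyl on it gives a 2.1-fold higher number from compound 1 to compound 3 (0.32 log units; beyond the scatter). The step is modest but lies beyond the scatter, which shows that inhibition of these cells responds to what this nitrogen carries, and that this replacement weakens it rather than preserving it. The change alters both the unit joined to the nitrogen and the substituent on the aromatic ring, so this one pair cannot show which part matters, and no measurement here explains the step.

Comparing (4-nitrophenyl)carbamoyl and (4-methoxyphenyl)thiocarbamoyl on the same nitrogen and the same core would separate those two parts, each differing from compound 1 or compound 3 in only one feature. From the compounds shown here alone, how far this position can be pushed also remains open, for example with a small acetyl group or a plain phenylcarbamoyl group in place of the substituted aromatic ones.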